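The source may hold more compounds than are shown below. What is called first, only, known or untested is meant among the compounds shown, and "the series" means these compounds.

Going by the values given here, in a functional assay on NUGC-3 cells (Homo sapiens) for antiproliferative activity, read by sulforhodamine B assay (on this read-out lower numbers stand for stronger inhibition of growth and higher numbers for weaker inhibition of growth), compound 1 (`CC(C)CCCOc1cccc(O)c1C(=O)/C=C/c1ccc(O)cc1`) gives 3520 nM, the only true number in this small set. Compound 2 (`CC(C)=CCOc1cccc(O)c1C(=O)/C=C/c1ccc(O)cc1`) reads > 30000 nM, which is a limit of the assay. Compound 3 (`O=C(/C=C/c1ccc(O)cc1)c1c(O)cccc1OCC1CCCCC1`) reads > 30000 nM, which is also a limit. Among the compounds with values here, the remaining two compounds therefore sit at the limit of > 30000 nM in this assay, at which 2 of the 3 values shown sit, and compound 1 is the only one with a measured value.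

The next compound is compound 4 (`O=C(/C=C/c1ccc(O)cc1)c1c(O)cccc1OCC1CCCC1`), with cyclopentyl in place of isopentyl on a saturated chain carbon bound to an oxygen on an aromatic ring. Within the data shown here, two measured steps bear on this change, and both lie beyond the scatter and are known only as minimum sizes. The change to 2-methylprop-1-en-1-yl gives an at least 8.5-fold higher number from compound 1 to compound 2 (0.93 log units; beyond the scatter). The change to cyclohexyl gives an at least 8.5-fold higher number from compound 1 to compound 3 (0.93 log units; beyond the scatter), and this is the closer guide, as cyclohexyl is also a carbon ring. Neither measured change away from isopentyl kept the activity, although two examples make a thin basis. A higher number is therefore expected in this assay, meaning weaker inhibition of growth, and a reading at the limit would be unsurprising. The expected step is a 5.7-fold higher number from compound 1 to compound 4 (0.75 log units; beyond the scatter). For compound 4 the estimate is 20000 nM, with an expected range of 7000 nM to 60000 nM.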

Compound 4, concentration for 50% growth inhibition: 2140 nM
Compound 4: the middle estimate sits 9.3-fold (0.97 log units) above what was measured; the whole stated range lies above it.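

In this assay, a carbon ring as such does not cost activity at this place: cyclopentyl in place of isopentyl on a saturated chain carbon bound to an oxygen on an aromatic ring gives a 1.6-fold lower number from compound 1 to compound 4 (0.22 log units; within the scatter), so these two groups cannot be told apart here. Ring size does separate the two carbon rings shown, with cyclopentyl in place of cyclohexyl giving an at least 14-fold lower number from compound 3 to compound 4 (1.14 log units; beyond the scatter), and the saturated ring also reads apart from the unsaturated chain, with cyclopentyl in place of 2-methylprop-1-en-1-yl giving an at least 14-fold lower number from compound 2 to compound 4 (1.14 log units; beyond the scatter). Both of these are minimum sizes, as compound 2 and compound 3 each stand at a limit of the assay and not at a number: the limit of > 30000 nM in this assay, at which 2 of the 4 values shown sit.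

Still open, as far as these compounds go, is whether activity at this place holds with a smaller carbon ring such as cyclobutyl, with an oxygen-containing ring such as tetrahydrofuranyl, or with a chain longer than 4-methylpentyl. From the compounds shown here alone, the full size of the steps to compound 2 and compound 3 also remains unknown, and the step between those two compounds cannot be read.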